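From a methyl to two methoxy groups on the amide

The source may report more compounds than this note shows. Statements on the series, on what has been measured and on what is new or still open speak of the compounds shown alone.

Compound 1 `Cc1ccc(C(=O)Nc2ccc(C(=O)/C=C/c3nc(C)c(C)nc3C)cc2)cc1` gives 9990 nM in a functional assay on A549 cells (Homo sapiens) for antiproliferative activity, read by CCK-8 assay, with a stated time of 72 h (a lower number here means a stronger inhibitor, a higher number a weaker inhibitor), the highest of the two numbers measured there. Its nearest neighbour is compound 2 `COc1ccc(C(=O)Nc2ccc(C(=O)/C=C/c3nc(C)c(C)nc3C)cc2)cc1`, which in this assay gives 4150 nM. Within the data shown here, the single measured step, methoxy in place of methyl on an aromatic carbon, produced a 2.4-fold lower number from compound 1 to compound 2 (0.38 log units; beyond the scatter), a modest change beyond the scatter. Compound 3 `COc1cc(OC)cc(C(=O)Nc2ccc(C(=O)/C=C/c3nc(C)c(C)nc3C)cc2)c1` differs from compound 1 by 3,5-dimethoxyphenyl in place of 4-methylphenyl on a carbonyl carbon. The measured step bears on this change only loosely, since the entering group is 3,5-dimethoxyphenyl rather than a single methoxy in place of methyl, so a modest lowering in this assay is expected, possibly none beyond the scatter. Compound 3 is therefore estimated to give 5000 nM, expected to fall between 1500 nM and 15000 nM, which would be a step of a 2.0-fold lower number from compound 1 to compound 3 (0.30 log units; within the scatter).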

Compound 3, half-maximal inhibitory concentration: 10200 nM
Compound 3: middle estimate off by 2.0-fold (0.31 log units), on the low side; the range from low to high includes it.
By their numbers in this assay, from the lowest: compound 2; then compounds 1 and 3 (each within the scatter of the next).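

In this assay, 3,5-dimethoxyphenyl in place of 4-methylphenyl on a carbonyl carbon gives a 1.0-fold higher number from compound 1 to compound 3 (0.01 log units; within the scatter) and so no measurable gain over the methyl-bearing ring. Set against the single methoxy group, the same group gives a 2.5-fold higher number from compound 2 to compound 3 (0.39 log units; beyond the scatter) so the lower number seen with 4-methoxyphenyl does not simply extend to a ring with more methoxy groups, and compound 3 goes against any such trend. Nothing measured here accounts for this difference.

The three compounds leave open whether the number of methoxy groups or their place on the ring matters, as 3,5-dimethoxyphenyl differs from 4-methoxyphenyl in both. Going by these compounds, how a 3-methoxyphenyl group, or a phenyl ring carrying an amine or a carboxylic acid, would behave on this carbonyl carbon also remains open.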